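Chlorophenyl in Place of Pyridinyl in a Cytotoxicity Series

A few compounds are considered here, and "the series" means these few. Any claim that something is new, unique, unknown or untested is made for them only; others in the source may bear on it.

Measured compounds:
Compound 1 `N#Cc1cccc(C(c2ccccc2)N2CCN(c3ncnc4c3cnn4-c3ccccc3)CC2)c1` gives > 25000 nM in a functional assay on cells (Rhabdomyosarcoma cell, Homo sapiens) for cytotoxicity; on this read-out higher numbers stand for weaker inhibition and lower numbers for stronger inhibition.
Compound 2 `c1ccc(C(c2ccccn2)N2CCN(c3ncnc4c3cnn4-c3ccccc3)CC2)cc1` gives > 25000 nM in this assay.
Compound 3 `c1ccc(C(c2cccnc2)N2CCN(c3ncnc4c3cnn4-c3ccccc3)CC2)cc1` gives > 25000 nM in this assay.

Each of these three values is a limit of this assay, not a number. Compound 3 therefore stands at the limit, and the other two values shown are limits as well; all three sit together at the limit of > 25000 nM in this assay, at which 3 of the 3 values shown sit. The steps from compound 1 to compound 2 a step that the two limits leave unreadable from compound 1 to compound 2, from compound 1 to compound 3 a step that the two limits leave unreadable from compound 1 to compound 3 and from compound 2 to compound 3 a step that the two limits leave unreadable from compound 2 to compound 3 are all unreadable, so the measured data give no direction for any aromatic exchange at this position.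

Compound 4 `Clc1ccc(C(c2ccccc2)N2CCN(c3ncnc4c3cnn4-c3ccccc3)CC2)cc1` carries 4-chlorophenyl in place of pyridin-3-yl on a saturated chain carbon bound to an amine nitrogen in a ring and an aromatic carbon. Since every measured step is unreadable, the step from compound 3 to compound 4 is expected to be a step that the limit leaves unreadable from compound 3 to compound 4, with no readable direction. Compound 4 is therefore estimated at 30000 nM in this assay, within 12000 nM to 80000 nM, most likely again reported only as a limit.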

Compound 4, half-maximal inhibitory concentration: > 25000 nM
Compound 4: only a limit was reported; the forecaster's own chance of this, stated with the estimate: 75%; the middle value lies beyond the limit too.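

In this assay compound 4 gives > 25000 nM as a limit and not a number. Its steps from compound 1, compound 2 and compound 3 cannot be read, and all four compounds sit together: the limit of > 25000 nM in this assay, at which 4 of the 4 values shown sit.
The compounds shown leave open whether any aromatic group at this position gives a measurable cytotoxic effect.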